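Variation at one ring carbon of the shared core

The source may hold more compounds than are shown below. What is called first, only, known or untested is meant among the compounds shown, and "the series" means these compounds.

Working notes on the series. Compound 1 `N#CC1=C(N)Oc2nc(Nc3ccc(S(N)(=O)=O)cc3)sc2C1c1ccc(Cl)cc1`, compound 2 `CC(=O)NC1=C(C#N)C(c2ccc(Cl)cc2)c2sc(Nc3ccc(S(N)(=O)=O)cc3)nc2O1` and compound 3 `N#CC1=C(/N=C/c2ccccc2)Oc2nc(Nc3ccc(S(N)(=O)=O)cc3)sc2C1c1ccc(Cl)cc1` have been measured in a functional assay on MCF7 cells (Homo sapiens) for antiproliferative activity, read by sulforhodamine B assay, with a stated time of 48 h; on this read-out higher numbers stand for weaker inhibition and lower numbers for stronger inhibition. In this assay compound 1 gives 39400 nM, compound 2 gives 41900 nM and compound 3 gives 45200 nM. Compound 3 stands at the highest of the three numbers, yet its gaps to compound 2 and to compound 1 both lie within the scatter, so no ranking among the three can be read. Compound 4 `N#CC1=C(NS(=O)(=O)c2ccccc2)Oc2nc(Nc3ccc(S(N)(=O)=O)cc3)sc2C1c1ccc(Cl)cc1` is the next member and carries a group of 10 heavy atoms (6 carbon, 1 nitrogen, 2 oxygen, 1 sulfur; one six-membered aromatic ring of carbon only) in place of a group of 8 heavy atoms (7 carbon, 1 nitrogen; one six-membered aromatic ring of carbon only), on a double-bonded ring carbon. Among the compounds with values here, three measured steps touch the same ring carbon: a 1.1-fold higher number from compound 1 to compound 2 (0.03 log units; within the scatter), a 1.1-fold higher number from compound 1 to compound 3 (0.06 log units; within the scatter) and a 1.1-fold higher number from compound 2 to compound 3 (0.03 log units; within the scatter). Each stayed within the scatter, so a further change at this position is expected to give no step beyond the scatter in this assay. The estimate for compound 4 is therefore 45000 nM, with a range from 20000 nM to 100000 nM. The expected step is a 1.0-fold lower number from compound 3 to compound 4 (0.00 log units; within the scatter).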

Compound 4, half-maximal inhibitory concentration: 47500 nM
Compound 4: the middle estimate sits 1.1-fold (0.02 log units) below what was measured; low and high end bracket the measured number.
By their numbers in this assay, from the lowest: compounds 1, 2, 3 and 4 (each within the scatter of the next).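

Within the data shown here, the (phenylsulfonyl)amino group places a sulfonyl unit on this ring carbon, something the earlier compounds did not carry, and the read-out in this assay still shows no step beyond the scatter: a 1.1-fold higher number from compound 3 to compound 4 (0.02 log units; within the scatter), a 1.1-fold higher number from compound 2 to compound 4 (0.05 log units; within the scatter) and a 1.2-fold higher number from compound 1 to compound 4 (0.08 log units; within the scatter). On the amine nitrogen, phenylsulfonyl therefore cannot be told apart from hydrogen or from acetyl, and all four compounds at this position remain within the scatter of one another. Nothing available explains why this position gives no readable step.

A dimethylamino group or a carboxylic acid on this ring carbon would test whether the flat picture extends beyond the groups shown. Going by these compounds, all four compounds also keep the 4-chlorophenyl group and the cyano group, so whether changing either one would give a step beyond the scatter remains open.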